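Quinoxaline in Place of Benzimidazole on the Shared Core

The source may report more compounds than this note shows. Statements on the series, on what has been measured and on what is new or still open speak of the compounds shown alone.

Two compounds built on the core of compound 1 `COc1cc2ncnc(N3CCC(CN4CCN(c5cccc(C(F)(F)F)c5)CC4)C3)c2cc1OC` have been measured in an assay on membranes from CHO-K1 cells for displacement of a labelled ligand from 5-hydroxytryptamine receptor 7 (Homo sapiens), read by scintillation counting; a lower number here means a stronger inhibitor, a higher number a weaker inhibitor. Compound 1 gives 229 nM. Compound 2 `COc1cc2ncnc(N3CCN(Cc4nc5ccccc5[nH]4)CC3)c2cc1OC` is a different case: in this assay compound 2 gives > 1000 nM, which is a limit of the assay and not a number. Compound 2 therefore stands at the limit of > 1000 nM in this assay, at which 1 of the 2 values shown sits, and how far beyond it lies cannot be read from the data.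

Compound 3 `COc1cc2ncnc(N3CCN(Cc4cnc5ccccc5n4)CC3)c2cc1OC` has not yet been measured. It differs from compound 2 by quinoxalin-2-yl in place of 1H-benzimidazol-2-yl on a saturated chain carbon bound to an amine nitrogen in a ring. For the measured compounds named here, no measured pair shows what this exchange does, so the size of the step rests on expectation alone. Since compound 2 sits at a limit, any move in this assay that stays weak would not be seen as a number at all. Compound 3 is expected to give about 1500 nM, somewhere between 500 nM and 5000 nM. The estimated step that the limit leaves unreadable from compound 2 to compound 3 is expected to lie within the scatter rather than beyond it.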

Compound 3, inhibition constant: > 1000 nM
Compound 3 was reported as a limit (the forecaster's own chance of this, stated with the estimate: 55%); the middle value lies beyond the limit too.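

In this assay, for the compounds shown here, compound 2 and compound 3 both stand at a limit of the assay and not at a number, so no step between them can be read: the limit of > 1000 nM in this assay, at which 2 of the 3 values shown sit.

The compounds shown leave open how far beyond that limit each lies, and so what quinoxalin-2-yl in place of 1H-benzimidazol-2-yl does.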